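Naphthalen-2-yl Replaces Fluorophenyl in a Cytotoxicity Series

A few compounds are considered here, and "the series" means these few. Any claim that something is new, unique, unknown or untested is made for them only; others in the source may bear on it.

Among the compounds with values here, in a functional assay on C8166 cells (Homo sapiens) for cytotoxicity, read by MTT assay (on this read-out lower numbers stand for higher toxicity in this test and higher numbers for lower toxicity in this test), compound 1 `Cc1cc(S(N)(=O)=O)ccc1NC(=O)COc1ccc(Cl)cc1NC(=O)c1cccc(F)c1` gives 243000 nM, the highest of the two numbers measured so far. Compound 2 `Cc1ccc(C(=O)Nc2cc(Cl)ccc2OCC(=O)Nc2ccc(S(N)(=O)=O)cc2C)cc1C` gives 84100 nM. Compound 3 `Cc1cc(S(N)(=O)=O)ccc1NC(=O)COc1ccc(Cl)cc1NC(=O)c1ccc2ccccc2c1` differs from compound 1 in one place: naphthalen-2-yl in place of 3-fluorophenyl on a carbonyl carbon. Within the data shown here, the only measured step at that same carbonyl carbon is a 2.9-fold lower number from compound 1 to compound 2 (0.46 log units; beyond the scatter), a modest move toward a lower number, and nothing else bears on this change. A step of similar direction and modest size is therefore expected, namely a 2.7-fold lower number from compound 1 to compound 3 (0.43 log units; beyond the scatter). Compound 3 is thus estimated to give 90000 nM, within a range from 30000 nM to 250000 nM.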

Compound 3, half-maximal cytotoxic concentration: 37600 nM
Estimate against measurement, compound 3: 2.4-fold (0.38 log units) above, within the range that was stated.
By their numbers in this assay, from the lowest: compound 3; then compound 2; then compound 1.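

In this assay, exchanging 3-fluorophenyl for naphthalen-2-yl on this carbonyl carbon gives a 6.5-fold lower number from compound 1 to compound 3 (0.81 log units; beyond the scatter), so a second aromatic ring of carbon only takes the number lower still, towards higher toxicity in this test. The change also goes past the 3,4-dimethylphenyl group, with a 2.2-fold lower number from compound 2 to compound 3 (0.35 log units; beyond the scatter), so the three groups at this position now stand in a clear order. Nothing measured here explains why the number falls. From the compounds shown here alone, it remains open how a ring that is not aromatic, such as cyclohexyl, or a carboxylic acid on a short chain would behave at this carbonyl carbon.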